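Carboxy to hydrogen on the aromatic ring: compound 4

This account rests on a few compounds, and the source may have more. Where it says the series, first, only, none or still open, it means among the compounds named here.

The compounds share the core of compound 2 `CC(C)(C)c1cc2c(N/N=C/c3ccc(C(=O)O)cc3)ncnc2s1` and differ in what sits on the six-membered aromatic ring of carbon only. In a functional assay on PC-6 cells (Homo sapiens) for cytotoxicity, read by MTT assay, with a stated time of 3 days (a higher number here means a weaker inhibitor, a lower number a stronger inhibitor), compound 2 gives 7.22 ug/mL. Compound 1 `CC(C)(C)c1cc2c(N/N=C/c3ccc(O)cc3)ncnc2s1` carries hydroxy on an aromatic carbon. In this assay compound 1 gives > 10 ug/mL, which is a limit of the assay and not a number. Compound 3 `CC(C)(C)c1cc2c(N/N=C/c3ccc4c(c3)CNCC4)ncnc2s1` gives 0.069 ug/mL in this assay. Of the numbers shown, compound 2 has the highest; compound 3 lies far lower, beyond the scatter. Compound 4 `CC(C)(C)c1cc2c(N/N=C/c3ccccc3)ncnc2s1` differs from compound 2 by hydrogen in place of carboxy on an aromatic carbon. Going by the values given here, the only measured step at that carbon, an at least 1.3-fold lower number from compound 1 to compound 2 (0.14 log units; that floor lies within the scatter), rests on the limit of > 10 ug/mL in this assay, at which 1 of the 3 values shown sits, of compound 1 and gives only a floor that lies within the scatter. The measured steps therefore do not fix how far hydrogen in place of carboxy will move the number. Compound 4 is expected to give 3 ug/mL in this assay, with a range from 0.6 ug/mL to 10 ug/mL. The expected step of a 2.4-fold lower number from compound 2 to compound 4 (0.38 log units; beyond the scatter) is a moderate move to a lower number, not firmly beyond the scatter.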

Compound 4, half-maximal inhibitory concentration: 6.54 ug/mL
The estimate for compound 4 lay 2.2-fold (0.34 log units) below the measured number; the measured number falls inside the stated range.
By their numbers in this assay, from the lowest: compound 3; then compounds 4 and 2 (each within the scatter of the next). At a limit, above all of these: compound 1.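

Hydrogen in place of carboxy on this aromatic carbon gives a 1.1-fold lower number from compound 2 to compound 4 (0.04 log units; within the scatter), so this assay does not separate these two groups at this position. Going by these compounds alone, this is the first step at this carbon with a number at both ends; the earlier step gave only a floor. Hydrogen in place of hydroxy gives an at least 1.5-fold lower number from compound 1 to compound 4 (0.18 log units; that floor lies within the scatter), again only a floor, and the value of compound 1 remains a limit of the assay and not a number: the limit of > 10 ug/mL in this assay, at which 1 of the 4 values shown sits.

Going by these compounds, it remains open whether an amino group, a methoxy group or a longer chain at this carbon would move the number beyond the scatter. On these data alone, it also remains open whether hydrogen in place of carboxy would read the same on the other carbons of this ring.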